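Thiazolidine amides: bromo to methyl at the aryl position

The compounds below may be only part of what the source reports. "The series", "measured", "known", "first", "only" and "open" are said of these compounds alone.

Measured so far:
compound 1 `CCCCCCCCCCCCCCCCCCNC(=O)[C@H]1CSC(c2ccc(N(C)C)cc2)N1` 5300 nM
compound 2 `CCCCCCCCCCCCCCCCCCNC(=O)[C@H]1CSC(c2ccc(Br)cc2)N1` 13800 nM

In a functional assay on DU-145 cells (Homo sapiens) for antiproliferative activity, read by sulforhodamine B assay (a higher number here means a weaker inhibitor, a lower number a stronger inhibitor), compound 1 gives 5300 nM and compound 2 gives 13800 nM. Among the measured compounds shown here, the only step recorded in this assay, a 2.6-fold higher number from compound 1 to compound 2 (0.42 log units; beyond the scatter), is a modest one beyond the scatter, and it leaves compound 2 with the higher of the two numbers. Compound 3 `CCCCCCCCCCCCCCCCCCNC(=O)[C@H]1CSC(c2ccc(C)cc2)N1` carries the change (methyl in place of bromo on an aromatic carbon), on an aromatic carbon of a six-membered aromatic ring of carbon only, para to a large group. For the measured compounds named here, the sole step that bears on it is the one from compound 1 to compound 2; no methyl analogue has been measured, so the direction is uncertain. Compound 3 is expected to sit near compound 2, with the step of a 1.4-fold lower number from compound 2 to compound 3 (0.14 log units; within the scatter) not clearly beyond the scatter. The estimate for compound 3 in this assay is 10000 nM, within the range 4000 nM to 25000 nM.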

Compound 3, half-maximal inhibitory concentration: 10500 nM
Estimate against measurement, compound 3: 1.1-fold (0.02 log units) below, and the stated range covers the measured number.
By their numbers in this assay, from the lowest: compounds 1, 3 and 2 (each within the scatter of the next, the first and the last beyond it).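

In this assay, the exchange on an aromatic carbon para to a large group, 4-bromophenyl to 4-methylphenyl, gives a step within the scatter (a 1.3-fold lower number from compound 2 to compound 3 (0.12 log units; within the scatter)), so methyl and bromo are not separated at this position. The comparison with dimethylamino is also within the scatter (a 2.0-fold higher number from compound 1 to compound 3 (0.30 log units; within the scatter)), which places methyl close to both groups even though the step between those two lies beyond it (a 2.6-fold higher number from compound 1 to compound 2 (0.42 log units; beyond the scatter)). No measurement accompanies these numbers that could account for them.

Open, as far as these compounds go, is whether a carboxylic acid or a hydroxyl group at this position would give a number beyond the scatter of all three compounds. Also open, from the compounds shown here alone, is whether these small steps would hold with a shorter chain on the amide.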